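The source may hold more compounds than are shown below. What is called first, only, known or untested is meant among the compounds shown, and "the series" means these compounds.

Measured so far:
compound 1, `Cc1cc(O)cc(-c2nn(CC#N)cc2-c2ccnc(-c3ccc(Oc4ccccc4)cc3)c2)c1`: 87%
compound 2, `COc1cc(C)cc(-c2nn(CC#N)cc2-c2ccnc(-c3ccc(N(C)C)cc3)c2)c1`: 32%

Compound 1, `Cc1cc(O)cc(-c2nn(CC#N)cc2-c2ccnc(-c3ccc(Oc4ccccc4)cc3)c2)c1`, gives 87% in a functional assay on OVCAR-8 cells (Homo sapiens) for cytotoxicity, read by sulforhodamine B assay, with a stated time of 48 h, tested at 100 nM; a lower number here means a stronger effect, a higher number a weaker effect of the compound at the concentration tested. Compound 2, `COc1cc(C)cc(-c2nn(CC#N)cc2-c2ccnc(-c3ccc(N(C)C)cc3)c2)c1`, gives 32% in this assay, the lowest of the two numbers at hand; the gap to compound 1 lies beyond the scatter. Among the measured compounds shown here, compounds 1 and 2 differ in two places, so no single-point step between measured compounds can be read from them.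

Compound 3, `Cc1cc(O)cc(-c2nn(CC#N)cc2-c2ccnc(-c3ccc(N(C)C)cc3)c2)c1`, is compound 2 with one change: hydrogen in place of methyl on an oxygen on an aromatic ring. For the measured compounds named here, no measured pair isolates this change. Compound 1 carries the same hydroxy group and gives the higher number, but its second difference from compound 2 leaves that gap unassigned. A step of moderate size toward a weaker effect is taken as more likely than none, with wide uncertainty in both directions. Compound 3 is expected at 50%, range 25% to 80%. This estimate means a step of a number 18 percentage points higher from compound 2 to compound 3 (beyond the scatter).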

Compound 3, a percentage reported as activity, at one concentration (the size of the read-out at that concentration, not a potency): 89%
For compound 3 the middle estimate is 39 percentage points below the measured one; the measured number lies above the stated range.
By their numbers in this assay, from the lowest: compound 2; then compounds 1 and 3 (each within the scatter of the next).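

In this assay, methoxy to hydroxy on the 3-methoxy-5-methylphenyl group is a large step (a number 57 percentage points higher from compound 2 to compound 3 (beyond the scatter)), so in this pair the stronger effect stands with methoxy and the weaker with hydroxy. With hydroxy held constant, dimethylamino in place of phenoxy on an aromatic carbon gives a step within the scatter (a number 2 percentage points higher from compound 1 to compound 3 (within the scatter)), so this pair does not separate those two groups. No accompanying measurement offers an explanation for either step.

Going by these compounds, whether the methoxy to hydroxy step holds with phenoxy in place of dimethylamino remains open. Also open, on these data alone, is how an ethoxy group, a longer ether chain or an amine on this aromatic carbon would read against methoxy.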